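The source may hold more compounds than are shown below. What is called first, only, known or untested is meant among the compounds shown, and "the series" means these compounds.

Within this series, compound 2 `CS[C@@H]1O[C@H](COCc2ccccc2)[C@@H](O)[C@@H](OCc2ccc3ccccc3c2)[C@H]1NC(=O)CCN=C(N)N` gives 180 nM in an assay on CHO cells for displacement of a labelled ligand from somatostatin receptor type 4 (Homo sapiens) (a higher number here means a weaker inhibitor, a lower number a stronger inhibitor), the lowest of the two numbers recorded. Compound 1 `CS[C@@H]1O[C@H](COCc2ccc(Cl)cc2)[C@@H](O)[C@@H](OCc2ccc3ccccc3c2)[C@H]1NC(=O)CCN` gives 430 nM in this assay, a gap beyond the usual scatter. Compound 3 `CS[C@@H]1O[C@H](COCc2ccccc2)[C@@H](O)[C@@H](OCc2ccc3ccccc3c2)[C@H]1NC(=O)CCN` is not yet measured; it differs from compound 2 in one place: one nitrogen atom in place of a group of 4 heavy atoms (1 carbon, 3 nitrogen; no ring), on a saturated chain carbon, two bonds along the chain from a carbonyl carbon. For the measured compounds named here, no single-change step between measured compounds is available to set the size, so a moderate weakening is expected for compound 3, a 2.2-fold higher number from compound 2 to compound 3 (0.35 log units; beyond the scatter), because compound 1, which carries the same amino group, stands at 430 nM. Compound 3 is expected near 400 nM, within 150 nM to 1000 nM.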

Compound 3, half-maximal inhibitory concentration: 660 nM
The estimate for compound 3 lay 1.7-fold (0.22 log units) below the measured number; the measured number falls inside the stated range.
By their numbers in this assay, from the lowest: compound 2; then compounds 1 and 3 (each within the scatter of the next).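

Amino in place of the group of 4 heavy atoms (1 carbon, 3 nitrogen), on a saturated chain carbon, two bonds along the chain from a carbonyl carbon, gives a 3.7-fold higher number from compound 2 to compound 3 (0.56 log units; beyond the scatter) in this assay and so shows that this position responds to the change. Hydrogen in place of chloro on an aromatic carbon gives a 1.5-fold higher number from compound 1 to compound 3 (0.19 log units; within the scatter) and leaves no readable effect of that swap. Nothing at hand accounts for either step.

Open, from the compounds shown here alone, is how a longer chain carrying the amino group would compare at this position. Also open, going by these compounds, is whether bromo or methoxy on that aromatic carbon would move the number.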